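The source may report more compounds than this note shows. Statements on the series, on what has been measured and on what is new or still open speak of the compounds shown alone.

Measured so far in an assay on isolated protein (urine) for inhibition of Myeloperoxidase (Homo sapiens), read by spectrophotometry; a lower number here means a stronger inhibitor, a higher number a weaker inhibitor:
- compound 1 `CCCCCCCCn1nc2ccccc2c1OC` gives > 10000 nM (a limit of this assay, not a number)
- compound 2 `COCCn1nc2ccccc2c1OC` gives 1080 nM
- compound 3 `CC(C)n1[nH]c2ccccc2c1=O` gives 660 nM

Compound 1 reaches only the assay limit, (the limit of > 10000 nM in this assay, at which 1 of the 3 values shown sits). Of the two plain numbers, compound 3 holds the smaller one, but the gap to compound 2 is within the scatter, so no order between them is claimed.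

Compound 4 `CCCCn1[nH]c2ccccc2c1=O` differs from compound 3 by butyl in place of isopropyl on an aromatic nitrogen. Going by the values given here, the only measured step, an at least 9.2-fold lower number from compound 1 to compound 2 (0.96 log units; beyond the scatter), concerns a group on a chain carbon and different groups, so it bears only loosely on this change. With nothing closer to rest on, the step of a 1.1-fold lower number from compound 3 to compound 4 (0.04 log units; within the scatter) is expected to stay within the scatter. Compound 4 is therefore estimated at 600 nM, within 200 nM to 1800 nM.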

Compound 4, half-maximal inhibitory concentration: 792 nM
The estimate for compound 4 lay 1.3-fold (0.12 log units) below the measured number, and the stated range covers the measured number.
By their numbers in this assay, from the lowest: compounds 3, 4 and 2 (each within the scatter of the next). At a limit, above all of these: compound 1.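

Butyl in place of isopropyl on an aromatic nitrogen gives a 1.2-fold higher number from compound 3 to compound 4 (0.08 log units; within the scatter) in this assay, so the two chains are not told apart at this position. This is the only step shown that compares two plain alkyl groups directly on the ring nitrogen, whereas the earlier step concerned a change on a chain carbon. No measured property on hand bears on this step.

Going by these compounds, it remains open whether a chain ending in an amine or a carboxylic acid on this nitrogen would shift the number beyond the scatter.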